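Amide chain variation in the series: compound 3 to compound 4

The source may hold more compounds than are shown below. What is called first, only, known or untested is meant among the compounds shown, and "the series" means these compounds.

Compound 1 `CCC1C(=O)N(C)c2cnc(-n3ccc4cc(C(N)=O)ccc43)nc2N1c1ccn(C)n1` gives "not active" (no number reported) in a functional assay on Huh-7 cells (Homo sapiens) for antiproliferative activity, read by CCK-8 assay, with a stated time of 72 h (a higher number here means a weaker inhibitor of growth, a lower number a stronger inhibitor of growth), with no number reported. Compound 2 `CCC1C(=O)N(C)c2cnc(-n3ccc4cc(C(=O)NC)ccc43)nc2N1c1ccn(C)n1` gives 13200 nM. Within the data shown here, compound 3 `CCC1C(=O)N(C)c2cnc(-n3ccc4cc(C(=O)NCC(C)C)ccc43)nc2N1c1ccn(C)n1` gives 5070 nM, the lowest of the two numbers, and the step of a 2.6-fold lower number from compound 2 to compound 3 (0.42 log units; beyond the scatter) is the only measured change. Compound 4 `CCCCNC(=O)c1ccc2c(ccn2-c2ncc3c(n2)N(c2ccn(C)n2)C(CC)C(=O)N3C)c1` differs from compound 3 by propyl in place of isopropyl on a saturated chain carbon bound to an amide-type nitrogen. Among the measured compounds shown here, the single measured step concerns adding isopropyl where hydrogen stood, not joining the same atoms differently, so it offers no direct guide; with no measured step on this kind of difference, no change beyond the scatter in this assay is expected, and the estimated step is a 1.0-fold lower number from compound 3 to compound 4 (0.01 log units; within the scatter). Compound 4 is therefore expected at about 5000 nM, within 2000 nM to 12500 nM.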

Compound 4, concentration for 50% growth inhibition: 8670 nM
Estimate against measurement, compound 4: 1.7-fold (0.24 log units) below, within the range that was stated.
By their numbers in this assay, from the lowest: compounds 3, 4 and 2 (each within the scatter of the next, the first and the last beyond it).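

Moving from isopropyl to propyl at this position gives a 1.7-fold higher number from compound 3 to compound 4 (0.23 log units; within the scatter) in this assay, so isobutyl and butyl on the amide are not told apart here. The butyl amide also stays within the scatter of the methyl amide, with a 1.5-fold lower number from compound 2 to compound 4 (0.18 log units; within the scatter), whereas the isobutyl amide alone lay beyond it, with a 2.6-fold lower number from compound 2 to compound 3 (0.42 log units; beyond the scatter). No measured property bears on these differences. Going by these compounds, whether a longer chain such as hexyl moves the number beyond the scatter remains open. So does the effect of an amine or a carboxylic acid at the chain end.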